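The source may hold more compounds than are shown below. What is called first, only, known or untested is meant among the compounds shown, and "the series" means these compounds.

Values in a functional assay on HL-60 cells (Homo sapiens) for cytotoxicity, read by MTT assay, with a stated time of 72 h; a higher number here means a weaker inhibitor, a lower number a stronger inhibitor:
- compound 1 `O=S(=O)(c1ccc(F)cc1)c1nc2ccccc2nc1N1CCc2ccccc2C1`: 4080 nM
- compound 2 `O=S(=O)(c1ccccc1)c1nc2ccccc2nc1N1CCCC(O)C1`: 3020 nM
- compound 3 `O=S(=O)(c1ccc(Br)cc1)c1nc2ccccc2nc1N1CCCC(O)C1`: 3430 nM
- compound 4 `O=S(=O)(c1ccc(F)cc1)c1nc2ccccc2nc1N1CCCC(O)C1`: not yet measured

Compound 3 lies within the scatter of both compound 2, its nearest neighbour, and compound 1, the furthest from it. The next change gives compound 4, with fluoro in place of bromo on an aromatic carbon, para to a large group: fluoro in place of bromo on an aromatic carbon.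

Going by the values given here, only one measured step bears directly on this position, bromo in place of hydrogen on an aromatic carbon. That was a 1.1-fold higher number from compound 2 to compound 3 (0.06 log units; within the scatter), so the one substitution tested here left the number within the scatter. Compound 1 already carries the 4-fluorophenyl group, with a different group on the shared core, and gives 4080 nM. No step beyond the scatter is therefore expected in this assay.

The expected step is a 1.0-fold lower number from compound 3 to compound 4 (0.02 log units; within the scatter). The estimate for compound 4 is 3300 nM, with an expected range of 2000 nM to 5300 nM.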

Compound 4, half-maximal inhibitory concentration: 2620 nM
Estimate against measurement, compound 4: 1.3-fold (0.10 log units) above, within the range that was stated.
By their numbers in this assay, from the lowest: compounds 4, 2, 3 and 1 (each within the scatter of the next).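

In this assay, the aromatic position para to a large group can now be compared across hydrogen, bromo and fluoro with the 3-hydroxypiperidin-1-yl group held constant: fluoro in place of bromo gives a 1.3-fold lower number from compound 3 to compound 4 (0.12 log units; within the scatter), and fluoro in place of hydrogen gives a 1.2-fold lower number from compound 2 to compound 4 (0.06 log units; within the scatter), so neither change leaves the scatter. With the 4-fluorophenyl group held constant, the other site also gets its first one-place comparison, and 3-hydroxypiperidin-1-yl in place of 1,2,3,4-tetrahydroisoquinolin-2-yl gives a 1.6-fold lower number from compound 1 to compound 4 (0.19 log units; within the scatter), again within the scatter. No available measurement offers an explanation for these steps.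

Going by these compounds, whether a methoxy group, a nitrile or an amine on the phenyl ring would also stay within the scatter remains open. The same question stands for a carboxylic acid or a longer chain in place of the 3-hydroxypiperidin-1-yl group.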